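The source may hold more compounds than are shown below. What is called first, only, known or untested is meant among the compounds shown, and "the series" means these compounds.

Measured compounds:
- Compound 1 `CN1CCN(C(=S)SC(=S)N(C)C)CC1` in an ADME assay on HeLa cells (Homo sapiens) for cytotoxicity, read by MTT assay, with a stated time of 24 h (a higher number here means a weaker inhibitor, a lower number a stronger inhibitor), gives 1220000 nM
- Compound 2 `CCCCN1CCN(C(=S)SC(=S)N(C)C)CC1` in this assay gives 4100000 nM
- Compound 3 `CN(C)C(=S)SC(=S)N1CCN(c2ncccn2)CC1` in this assay gives only a limit, > 5000000 nM

Compound 3 sits at the top of what was measured, since its reading is a limit of this assay rather than a number (the limit of > 5000000 nM in this assay, at which 1 of the 3 values shown sits). The step to compound 4 `CSC(=S)N1CCN(C(=S)SC(=S)N(C)C)CC1` changes the group on the ring nitrogen: a group of 4 heavy atoms (2 carbon, 2 sulfur; no ring) in place of a group of 6 heavy atoms (4 carbon, 2 nitrogen; one six-membered aromatic ring with 2 hetero atoms), on an amine nitrogen in a ring. For the measured compounds named here, none of the measured steps involves this new group. The closest comparisons are a 3.4-fold higher number from compound 1 to compound 2 (0.53 log units; beyond the scatter) and an at least 4.0-fold higher number from compound 1 to compound 3 (0.61 log units; beyond the scatter), both showing that enlarging the group on that nitrogen gave a higher number, while an at least 1.2-fold higher number from compound 2 to compound 3 (0.08 log units; that floor lies within the scatter) is too small to read. Since compound 3 already stands at a limit of this assay, a step of clear size in either direction cannot be firmly expected; the estimate for compound 4 is 4000000 nM, ranging from 1000000 nM to 20000000 nM. This estimate corresponds to an expected step of an at least 1.2-fold lower number from compound 3 to compound 4 (0.09 log units; that floor lies within the scatter).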

Compound 4, half-maximal inhibitory concentration: > 5000000 nM
Compound 4: a limit, no number; the forecaster's own chance of this, stated with the estimate: 50%; middle value at least 1.2-fold (0.09 log units) from the limit.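

The step from compound 3 to compound 4 cannot be read, because both compounds stop at the same limit rather than giving numbers: the limit of > 5000000 nM in this assay, at which 2 of the 4 values shown sit. The new information is that this group with no ring, made of carbon and sulfur, also gives an at least 4.0-fold higher number from compound 1 to compound 4 (0.61 log units; beyond the scatter) in place of the one carbon of compound 1, so all three larger groups shown on this amine nitrogen read higher than methyl, with no compound going against that. Compared with butyl, a group of the same heavy-atom count, the result is an at least 1.2-fold higher number from compound 2 to compound 4 (0.08 log units; that floor lies within the scatter) and no difference between the two groups can be claimed.

Going by these compounds, how far compound 3 and compound 4 actually lie beyond the limit stays open. Also open, on these data alone, is how a hydrogen, an ethyl chain or a chain ending in a carboxylic acid on this nitrogen would read.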